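The source may hold more compounds than are shown below. What is called first, only, known or untested is meant among the compounds shown, and "the series" means these compounds.

Three compounds from one series have so far been examined in a functional assay on HOP-92 cells (Homo sapiens) for cytotoxicity, read by sulforhodamine B assay, with a stated time of 48 h, tested at 0.01 uM; a higher number here means a weaker effect of the compound at the concentration tested, a lower number a stronger effect. Compound 1, `COc1cc(C)cc(-c2c(-c3ccnc(-c4ccc(N(C)C)cc4)c3)cnn2CC#N)c1`, gives -9%. Compound 2, `COc1cc(C)cc(-c2nn(CC#N)cc2-c2ccnc(-c3ccc(N(C)C)cc3)c2)c1`, gives 93%. Compound 3, `COc1cc(C)cc(-c2nn(CC#N)cc2-c2ccc(-c3cccc(C(C)=O)c3)nc2)c1`, gives 80%. On these numbers compound 2 stands highest of the three: its nearest neighbour is compound 3, whose number lies below it by a margin beyond the scatter, and its furthest is compound 1, whose number lies far below it. Among the measured compounds shown here, no step between these measured compounds has been worked out, so only the values themselves can be compared.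

The next compound, compound 4, is `Cc1cc(O)cc(-c2nn(CC#N)cc2-c2ccnc(-c3ccc(N(C)C)cc3)c2)c1`. It differs from compound 2 in a single place: hydrogen in place of methyl on an oxygen on an aromatic ring. For the measured compounds named here, no measured pair in this set shows the effect of this change, so nothing in the data fixes its size or direction. Compound 2 sits near the top of the range, which leaves little room for a rise, so the expected step of a number 18 percentage points lower from compound 2 to compound 4 (beyond the scatter) in this assay is a modest fall, though a result within the scatter would not surprise. On that basis compound 4 is expected to give about 75% in this assay, between 30% and 100%.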

Compound 4, a percentage reported as activity, at one concentration (the size of the read-out at that concentration, not a potency): 85%
Compound 4: the middle estimate sits 10 percentage points below what was measured, within the range that was stated.
By their numbers in this assay, from the lowest: compound 1; then compounds 3, 4 and 2 (each within the scatter of the next, the first and the last beyond it).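

Among the compounds shown here, removing the methyl from the oxygen on the aromatic ring, so that 3-methoxy-5-methylphenyl becomes 3-hydroxy-5-methylphenyl, gives in this assay the first single-place comparison in this set: a number 8 percentage points lower from compound 2 to compound 4 (within the scatter). At this concentration, methoxy and hydroxy at this place therefore cannot be told apart, with compound 2 at 93% and compound 4 at 85%. For the compounds shown here, this reading rests on one pair, and both compounds have high numbers in a read-out where a higher number means a weaker effect, so it shows only that this change leaves compound 2 without a clear shift in this assay. No measurement in hand explains why the number stays within the scatter.

As far as these compounds go, it remains open whether an ethoxy group or a longer chain on that oxygen, or an amine in place of the oxygen, would move the number beyond the scatter. From the compounds shown here alone, it is also open whether the same change from methoxy to hydroxy would leave the number as little altered on the core of compound 1, which gives -9%.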